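This account rests on a few compounds, and the source may have more. Where it says the series, first, only, none or still open, it means among the compounds named here.

Within the data shown here, compound 3, `COc1cc(C2=NN(C(C)=O)C(c3cccc(OC)c3OC)O2)cc(OC)c1OC`, is one of three compounds measured in a functional assay on BGC-823 cells (Homo sapiens) for antiproliferative activity, read by MTT assay, tested at 5 uM; on this read-out higher numbers stand for a stronger effect at the one concentration tested and lower numbers for a weaker effect. Compound 3 gives 17.5%, the second highest of the three numbers. The nearest is compound 1, `COc1ccc(/C=N/NC(=O)c2cc(OC)c(OC)c(OC)c2)c(OC)c1`, which gives 3.6%, a number lower by more than the usual scatter. The furthest is compound 2, `COc1cc(C(=O)N/N=C/c2cccc(F)c2)cc(OC)c1OC`, which gives 44.8%, a number higher by more than the scatter. Among the measured compounds shown here, compound 3 differs from each of these in several places, so no single step among the three can be picked out.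

Compound 4, `COc1cc(C2=NN(C(C)=O)C(c3ccc(F)cc3)O2)cc(OC)c1OC`, has not yet been measured. It differs from compound 3 in one place: 4-fluorophenyl in place of 2,3-dimethoxyphenyl on a saturated ring carbon. For the measured compounds named here, no measured pair shows exactly this step, so its size is uncertain. The two open-chain compounds offer only a hint: compound 2, carrying a fluorine on its ring, gives 44.8%, while compound 1, carrying two methoxy groups, gives 3.6%, and these two differ in more than one place. For compound 4 the expected step is a number 17.5 percentage points higher from compound 3 to compound 4 (beyond the scatter), an upward move beyond the scatter. Compound 4 is estimated to give 35% in this assay, within a range from 15% to 55%.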

Compound 4, a percentage reported as inhibition, at one concentration (the size of the read-out at that concentration, not a potency): 13.3%
Beside the measured number, compound 4's estimate is 21.7 percentage points above it, outside the stated range (below it).
By their numbers in this assay, from the lowest: compounds 1, 4 and 3 (each within the scatter of the next, the first and the last beyond it); then compound 2.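

Among these compounds, putting 4-fluorophenyl in place of 2,3-dimethoxyphenyl on the saturated ring carbon gives a number 4.2 percentage points lower from compound 3 to compound 4 (within the scatter) in this assay and is the first step here that isolates a single change at a single place. The exchange is not a small one: the entering group has fewer heavy atoms, a fluorine instead of two methoxy groups, and none of the two hydrogen-bond acceptors counted on the group that leaves, yet the two compounds cannot be told apart at this one concentration. No measurement here explains why this exchange leaves the read-out within the scatter.

This single swap alters the number, kind and placement of the ring's substituents all at once, so it leaves open whether the two methoxy groups and the fluorine each matter alone or simply make no difference at this carbon. It also leaves open whether a quite different group on that carbon, such as an unsubstituted phenyl, a pyridine ring or a chain ending in an amine, would move the read-out beyond the scatter.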